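Thiosemicarbazone aryl ethers: lipophilicity notes

A few compounds are considered here, and "the series" means these few. Any claim that something is new, unique, unknown or untested is made for them only; others in the source may bear on it.

Measured so far:
Compound 1 `Cc1cc(Oc2ccc(/C=N/NC(=S)Nc3ccc(Br)cc3)cc2)ccc1Cl` — 7.89
Compound 2 `S=C(N/N=C/c1ccc(Oc2ccc3ccccc3c2)cc1)Nc1ccc(Cl)cc1` — 6.96

In a physicochemical assay for lipophilicity, in phosphate buffer, measured as octanol-water partition, with a stated time of 24 h (on this read-out lower numbers stand for lower lipophilicity and higher numbers for higher lipophilicity), compound 1 gives 7.89 and compound 2 gives 6.96. Compound 2 stands lowest of the two numbers; the nearest value, that of compound 1, is higher by a gap that lies beyond the scatter. Among the compounds with values here, the two compounds differ in more than one place, so their values show only that compound 1 is the more lipophilic of the pair.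

The next compound, compound 3 `Fc1ccc(Oc2ccc(/C=N/NC(=S)Nc3ccc(Cl)cc3)cc2)cc1`, follows from compound 2 through one change:
4-fluorophenyl in place of naphthalen-2-yl on an oxygen on an aromatic ring

Within the data shown here, no step between measured compounds covers this change, so there is no measured anchor for it. The expectation is a step downward in this assay, beyond the scatter, estimated at a number 1.06 log units lower from compound 2 to compound 3 (beyond the scatter) from compound 2 to compound 3. Compound 3 is therefore expected to give about 5.9, within a range from 5.3 to 6.5, placing it below both measured compounds.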

Compound 3, partition coefficient: 5.84
Estimate against measurement, compound 3: 0.06 log units above; measured number inside the range.
By their numbers in this assay, from the lowest: compound 3; then compound 2; then compound 1.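

In this assay, within the data shown here, 4-fluorophenyl in place of naphthalen-2-yl on an oxygen on an aromatic ring gives a number 1.12 log units lower from compound 2 to compound 3 (beyond the scatter), the first comparison that differs in one place only. The read-out at this position therefore depends on the group carried there, and the step is large even though the two groups have the same counts of hydrogen-bond donors and acceptors, and neither carries a net charge; what differs is one six-membered aromatic ring of carbon only in place of two, and seven heavy atoms, one of them fluorine, in place of heavy atoms that are all carbon. Nothing available bears on why the step has this size.

A single step cannot separate the loss of the second aromatic ring from the entry of fluorine, and a plain phenyl group, which would divide the two, is not among the compounds shown. Also open, going by these compounds, are how the read-out responds at this position to an amine or a carboxylic acid, and whether the step keeps its size on the core of compound 1.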